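From phenyl to vinyl on a shared core

The compounds below may be only part of what the source reports. "The series", "measured", "known", "first", "only" and "open" are said of these compounds alone.

Compound 1 `NC(=S)c1cn(Cc2ccccc2)c2ncnc(N)c12`: 70000 nM
Compound 2 `Cn1cc(C(=N)S)c2c(N)ncnc21`: 38000 nM

In a functional assay on L1210 cells (Mus musculus) for inhibition (on this read-out lower numbers stand for stronger inhibition and higher numbers for weaker inhibition), compound 1 gives 70000 nM and compound 2 gives 38000 nM, so the two stand within the usual scatter of each other. Compound 3 `C=CCn1cc(C(N)=S)c2c(N)ncnc21` has not yet been measured. It departs from compound 1 by one change: vinyl in place of phenyl on a saturated chain carbon bound to an aromatic nitrogen. In short, vinyl takes the place of phenyl on a saturated chain carbon bound to an aromatic nitrogen. No large step is expected in this assay because compound 1 at 70000 nM and compound 2 at 38000 nM sit so close together. The estimated step runs a 1.6-fold lower number from compound 1 to compound 3 (0.19 log units; within the scatter). For compound 3 the estimated value is 45000 nM, with an expected range from 15000 nM to 100000 nM.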

Compound 3, half-maximal inhibitory concentration: 38000 nM
Compound 3: the middle estimate sits 1.2-fold (0.07 log units) above what was measured; low and high end bracket the measured number.
By their numbers in this assay, from the lowest: compounds 2, 3 and 1 (each within the scatter of the next).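

In this assay putting vinyl in place of phenyl on a saturated chain carbon bound to an aromatic nitrogen gives no change beyond the scatter (a 1.8-fold lower number from compound 1 to compound 3 (0.27 log units; within the scatter)) and keeps the number in the same range. At this position, then, a six-membered aromatic ring of carbon only and a two-carbon group with no ring give readings that cannot be told apart. Nothing on hand explains this result.

Going by these compounds, what an amine, a carboxylic acid or a longer chain would give at this place stays open. So does whether any group here can move the number beyond the scatter.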